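The source may report more compounds than this note shows. Statements on the series, on what has been measured and on what is new or still open speak of the compounds shown alone.

In a functional assay on the whole organism (strain Wistar) for inhibition, with Rattus norvegicus as the target, read by paw edema, with stated times of 30 min and 3 h, at a dose of 0.05 mmol/kg by the oral route (a lower number here means less inhibition, a higher number more inhibition at the dose given (going by the name of the read-out)), compound 2 `Cc1cc(O)ccc1C1=NN(c2ccc(S(C)(=O)=O)cc2)C(=O)CC1` gives 33.3%, the second highest of the three numbers seen. Compound 1 `Cc1cc(C2=NN(c3ccc(S(C)(=O)=O)cc3)C(=O)CC2)ccc1O` gives 26.6%, and compound 3 `COc1ccc(C2=NN(c3ccc(S(C)(=O)=O)cc3)C(=O)CC2)cc1OC` gives 66.6%, a value beyond the scatter above compound 2. Compound 4 `Cc1ccc(O)c(C2=NN(c3ccc(S(C)(=O)=O)cc3)C(=O)CC2)c1` has not yet been measured; it differs from compound 2 by 2-hydroxy-5-methylphenyl in place of 4-hydroxy-2-methylphenyl on a carbon with a double bond to nitrogen, the same atoms being joined differently. Among the compounds with values here, one measured step bears on such a rearrangement of the hydroxy and methyl groups on the aromatic ring: the comparable shift gave a number 6.7 percentage points higher from compound 1 to compound 2 (within the scatter). Compound 4 is therefore expected to show a number 0.3 percentage points lower from compound 2 to compound 4 (within the scatter), a movement not beyond the scatter in either direction. Compound 4 is estimated at 33%, with a range from 15% to 52%.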

Compound 4, a percentage reported as inhibition, in the whole organism at one dose (the size of the read-out at that dose, not a potency): 66.6%
Estimate against measurement, compound 4: 33.6 percentage points below; measured number outside the range, above it.
By their numbers in this assay, from the lowest: compounds 1 and 2 (each within the scatter of the next); then compounds 3 and 4 (each within the scatter of the next).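

Within this assay the switch to 2-hydroxy-5-methylphenyl gives a number 33.3 percentage points higher from compound 2 to compound 4 (beyond the scatter) and a number 40 percentage points higher from compound 1 to compound 4 (beyond the scatter) with the same atoms, joined differently. The earlier shift among these hydroxy and methyl groups, a number 6.7 percentage points higher from compound 1 to compound 2 (within the scatter), stayed small, so this position had not yet shown that it could respond. The arrangement on this ring can therefore matter greatly, at least for the compounds shown.

No measurement here tells what lies behind the gain. As far as these compounds go, whether an amine or a carboxylic acid could take the place of the hydroxy group in 2-hydroxy-5-methylphenyl stays open.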